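The source may hold more compounds than are shown below. What is called first, only, known or untested is meant among the compounds shown, and "the series" means these compounds.

Measured in a functional assay on A549 cells (Homo sapiens) for inhibition, read by MTT assay, with a stated time of 72 h; on this read-out higher numbers stand for weaker inhibition and lower numbers for stronger inhibition:
- compound 1 `COc1cc2c(Oc3ccc(NC(=O)c4nn(-c5cccc(F)c5)c(=O)cc4C)cc3F)ccnc2cc1OCCCN1CCC(C)CC1` gives 250 nM
- compound 2 `COc1cc2c(Oc3ccc(NC(=O)c4nn(-c5cccc(F)c5)c(=O)cc4C)cc3F)ccnc2cc1OCCCN1CCN(C)CC1` gives 150 nM
- compound 3 `COc1ccc(-n2nc(C(=O)Nc3ccc(Oc4ccnc5cc(OCCCN6CCC(C)CC6)c(OC)cc45)c(F)c3)c(C)cc2=O)cc1` gives 1100 nM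

From compound 1 to compound 2 the change is 4-methylpiperazin-1-yl in place of 4-methylpiperidin-1-yl on a saturated chain carbon, three bonds along the chain from an oxygen on an aromatic ring, and the step is a 1.7-fold lower number from compound 1 to compound 2 (0.22 log units; within the scatter). Compound 3 carries a different core, separated from compound 1 by 4-methoxyphenyl in place of 3-fluorophenyl on an aromatic nitrogen, with the step of a 4.4-fold higher number from compound 1 to compound 3 (0.64 log units; beyond the scatter); compound 3 therefore holds the highest number of the three.

Compound 4 `COc1ccc(-n2nc(C(=O)Nc3ccc(Oc4ccnc5cc(OCCCN6CCN(C)CC6)c(OC)cc45)c(F)c3)c(C)cc2=O)cc1` is not yet measured. It stands to compound 3 as compound 2 stands to compound 1: the change is 4-methylpiperazin-1-yl in place of 4-methylpiperidin-1-yl on a saturated chain carbon, three bonds along the chain from an oxygen on an aromatic ring, and the place is described in the same words for both pairs, so this is the same change on the core of compound 3.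

The step is expected to resemble that of the measured pair, since compound 2 relative to compound 1 gave a 1.7-fold lower number from compound 1 to compound 2 (0.22 log units; within the scatter); an expected step of a 1.7-fold lower number from compound 3 to compound 4 (0.23 log units; within the scatter) follows. Compound 4 is thus estimated at 650 nM in this assay, expected to fall between 300 nM and 1400 nM.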

Compound 4, half-maximal inhibitory concentration: 2200 nM
Compound 4: the middle estimate sits 3.4-fold (0.53 log units) below what was measured, outside the stated range (above it).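

In this assay, 4-methylpiperazin-1-yl in place of 4-methylpiperidin-1-yl gives a 2.0-fold higher number from compound 3 to compound 4 (0.30 log units; within the scatter), and this does not match its result on the core of compound 1: the same change on two cores in this assay, a 1.7-fold lower number (0.22 log units; within the scatter) from compound 1 to compound 2 and a 2.0-fold higher number (0.30 log units; within the scatter) from compound 3 to compound 4, 3.3-fold (0.52 log units) apart, beyond the scatter of two such steps

Read the other way, 4-methoxyphenyl in place of 3-fluorophenyl gives a 15-fold higher number from compound 2 to compound 4 (1.17 log units; beyond the scatter), which also differs from its result on the first pair: the same change on two cores in this assay, a 4.4-fold higher number (0.64 log units; beyond the scatter) from compound 1 to compound 3 and a 15-fold higher number (1.17 log units; beyond the scatter) from compound 2 to compound 4, 3.3-fold (0.52 log units) apart, beyond the scatter of two such steps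

These two comparisons rest on the same four compounds, so they show one departure from additivity, not two independent ones, and they do not show its cause or whether it extends beyond these compounds.

Still open, from the compounds shown here alone, is whether this holds with morpholin-4-yl in place of 4-methylpiperidin-1-yl, or with a longer chain. An unsubstituted phenyl on the aromatic nitrogen would test the other side of the comparison.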